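Furan-2-yl for difluorophenyl on a thiophene series

A few compounds are considered here, and "the series" means these few. Any claim that something is new, unique, unknown or untested is made for them only; others in the source may bear on it.

Of the compounds shown here, three of one series have been measured in an assay on CHO cells for displacement of a labelled ligand from adenosine receptor A1 (Homo sapiens), read by scintillation counting, tested at 10 uM; on this read-out higher numbers stand for more inhibition at the one concentration tested (going by the name of the read-out) and lower numbers for less inhibition. Compound 1 `CC(C)(C)Cc1c(-c2cc(F)ccc2F)sc(N)c1C(=O)c1ccc(Cl)cc1` gives 3% in this assay. Compound 2 `CC(C)(C)Cc1c(Br)sc(N)c1C(=O)c1ccc(Cl)c(Cl)c1` gives 1% in this assay, and compound 3 `Cc1ccc(C(=O)c2c(N)sc(Br)c2CC(C)(C)C)cc1` gives 1%. Compound 1 has the largest of the three numbers, but compound 2 and compound 3 both lie within the usual scatter of it, so the three measurements show no separation: all three sit close to the bottom of the read-out.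

The next compound, compound 4 `CC(C)(C)Cc1c(-c2ccco2)sc(N)c1C(=O)c1ccc(Cl)cc1`, differs from compound 1 in one place: furan-2-yl in place of 2,5-difluorophenyl on an aromatic carbon. Within the data shown here, no step between measured compounds covers this kind of change, so nothing among the measured numbers points in either direction. Given that compound 1 gives 3% and that all measured numbers are near zero, compound 4 is expected to stay in the same region, with a step of a number 1 percentage points higher from compound 1 to compound 4 (within the scatter) that is not expected to exceed the scatter. For compound 4 the estimate in this assay is 4%, within a range from -6% to 14%.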

Compound 4, a percentage reported as inhibition, at one concentration (the size of the read-out at that concentration, not a potency): 1%
Compound 4: the middle estimate sits 3 percentage points above what was measured, within the range that was stated.
By their numbers in this assay, from the lowest: compounds 2, 3, 4 and 1 (each within the scatter of the next).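

In this assay, among these compounds, the first single change at this position, on the aromatic carbon next to the ring sulfur, gives a number 2 percentage points lower from compound 1 to compound 4 (within the scatter) and so leaves the two compounds unseparated. Going from a six-membered carbon ring bearing two fluorines to a smaller five-membered ring with one oxygen and one hydrogen-bond acceptor therefore shows no measurable consequence here, although both numbers lie so close to the bottom of the read-out that this single step cannot show what the change does in a compound with clear inhibition. No measurement at hand bears on the reason for this result.

From the compounds shown here alone, it remains open whether an aminomethyl group, a carboxylic acid or a longer alkyl chain at this position would lift the number clear of the scatter. Going by these compounds, it is equally open whether replacing the neopentyl group or the amino group on the shared core would do so.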